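Working notes: from compound 3 to compound 4

A few compounds are considered here, and "the series" means these few. Any claim that something is new, unique, unknown or untested is made for them only; others in the source may bear on it.

Measured so far in an ADME assay on microsomes from liver (Homo sapiens) for metabolic stability, read by LC-MS, with a stated time of 30 min, tested at 1 uM (on this read-out higher numbers stand for fast clearance and lower numbers for slow clearance), for the series:
- compound 1 `C[C@@H](c1ccc2ncccc2c1)c1nnc2ccc(-c3cccc(C#N)c3)nn12` gives 17.9 mL.min-1.g-1
- compound 2 `COc1ccc(-c2ccc3nnc([C@@H](C)c4ccc5ncccc5c4)n3n2)cc1F` gives 281 mL.min-1.g-1
- compound 3 `C[C@@H](c1ccc2ncccc2c1)c1nnc2ccc(-c3ccccc3C#N)nn12` gives 23.1 mL.min-1.g-1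

Compound 3 cannot be told apart from compound 1 and lies far under compound 2 on these numbers. The step of a 1.3-fold higher number from compound 1 to compound 3 (0.11 log units; within the scatter) marks the nearest neighbour and the step of a 12-fold lower number from compound 2 to compound 3 (1.09 log units; beyond the scatter) marks the furthest.

Compound 4 `CNC(=O)c1ccc(-c2ccc3nnc([C@@H](C)c4ccc5ncccc5c4)n3n2)cc1` carries 4-(methylcarbamoyl)phenyl in place of 2-cyanophenyl on an aromatic carbon, and the change counts as 4-(methylcarbamoyl)phenyl in place of 2-cyanophenyl on an aromatic carbon at the same place on the shared core.

Two kinds of measured step bear on it. The large step of a 16-fold higher number from compound 1 to compound 2 (1.20 log units; beyond the scatter) shows that a swap at this place can move the number strongly. The step of a 1.3-fold higher number from compound 1 to compound 3 (0.11 log units; within the scatter) stays small but only relocates the nitrile. For the measured compounds named here, no measured compound carries an amide, so the guidance is weak.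

The expected outcome is a 1.3-fold higher number from compound 3 to compound 4 (0.11 log units; within the scatter) and no shift beyond the scatter is expected. Compound 4 is estimated at 30 mL.min-1.g-1 within an expected range of 10 mL.min-1.g-1 to 90 mL.min-1.g-1 on this read-out.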

Compound 4, intrinsic clearance in microsomes: 12.2 mL.min-1.g-1
Estimate against measurement, compound 4: 2.5-fold (0.39 log units) above, within the range that was stated.
By their numbers in this assay, from the lowest: compounds 4, 1 and 3 (each within the scatter of the next); then compound 2.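

In this assay the swap to 4-(methylcarbamoyl)phenyl leaves the number within the scatter of both nitrile compounds (a 1.9-fold lower number from compound 3 to compound 4 (0.28 log units; within the scatter); a 1.5-fold lower number from compound 1 to compound 4 (0.17 log units; within the scatter)), while the gap to the 3-fluoro-4-methoxyphenyl compound stays large (a 23-fold lower number from compound 2 to compound 4 (1.36 log units; beyond the scatter)). A low number at this place therefore does not require a nitrile: a group with a hydrogen-bond donor and no triple bond falls in the same band as compound 1 and compound 3, and compound 2 alone stands apart. Nothing available explains why these groups sit together or why compound 2 differs.

Still open, as far as these compounds go, is how far this tolerance extends, for example to a carboxylic acid or a primary amine on the phenyl ring. Also open, from the compounds shown here alone, is whether the fluorine or the methoxy group of compound 2 accounts for its high number, as the two are not separated here.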